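Removing a methoxy group from compound 2

The compounds below may be only part of what the source reports. "The series", "measured", "known", "first", "only" and "open" are said of these compounds alone.

Of the compounds shown here, three sharing one core have been tested in a functional assay on HSG cells (Homo sapiens) for cytotoxicity; on this read-out lower numbers stand for higher toxicity in this test and higher numbers for lower toxicity in this test. For compound 1 `COc1cc(/C=C2\CC/C(=C\c3ccc([N+](=O)[O-])cc3)C2=O)cc(OC)c1OC` the read-out is > 400000 nM, which is a limit of the assay and not a number. Compound 3 `COc1ccc(/C=C2\CCC/C(=C\c3ccc([N+](=O)[O-])cc3)C2=O)cc1OC` gives 13000 nM in this assay. Compound 2 `COc1cc(/C=C2\Cc3ccccc3/C(=C\c3ccc([N+](=O)[O-])cc3)C2=O)ccc1O` gives 5800 nM in this assay, the lowest of the two numbers; the nearest number, that of compound 3, lies above it by more than the usual scatter of repeated measurements.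

Compound 4 `O=C1/C(=C/c2ccc(O)cc2)Cc2ccccc2/C1=C\c1ccc([N+](=O)[O-])cc1` has not yet been measured. It differs from compound 2 by hydrogen in place of methoxy on an aromatic carbon; read one bond further out, the change is 4-hydroxy-3-methoxyphenyl to 4-hydroxyphenyl. Within the data shown here, no pair of measured compounds differs by this change alone, so the size of the step rests on expectation only. The three measured compounds show that the pattern of oxygen substituents on this ring goes along with large differences in this assay, but none of them isolates the methoxy group in question. The step from compound 2 to compound 4 is expected to be small, a 1.4-fold higher number from compound 2 to compound 4 (0.14 log units; within the scatter), most likely within the scatter or slightly toward a higher number. Compound 4 is therefore estimated at 8000 nM in this assay, with a range from 2500 nM to 25000 nM.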

Compound 4, half-maximal cytotoxic concentration: 11000 nM
Compound 4: middle estimate off by 1.4-fold (0.14 log units), on the low side; low and high end bracket the measured number.
By their numbers in this assay, from the lowest: compounds 2, 4 and 3 (each within the scatter of the next, the first and the last beyond it). At a limit, above all of these: compound 1.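

In this assay, among these compounds, a single change at this position can now be read for the first time: a 1.9-fold higher number from compound 2 to compound 4 (0.28 log units; within the scatter). Replacing the methoxy group with hydrogen, on an aromatic carbon ortho to a hydroxy group, therefore gives two numbers that cannot be told apart, so on this core the 4-hydroxyphenyl ring serves as well as the 4-hydroxy-3-methoxyphenyl ring in this test. This is one step on one core, and it does not account for the wider spread among the earlier compounds, which differ from one another in more than one place.

Compound 1 remains a limit of the assay and not a number, so it cannot be placed in any order with the others: the limit of > 400000 nM in this assay, at which 1 of the 4 values shown sits. On these data alone, it stays open how this position would respond to an amine, a fluorine atom or a longer alkoxy chain in place of the methoxy group, and whether the same step would read alike on the cores of compound 1 and compound 3.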